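The source may hold more compounds than are shown below. What is called first, only, known or untested is meant among the compounds shown, and "the series" means these compounds.

Among the compounds with values here, compound 2 `CCCC(Oc1ccc(-n2cc(C(=O)N(C)C)cn2)cc1)c1ccc(C(=O)NCCC(=O)O)cc1` gives 6500 nM in an assay on cells for displacement of a labelled ligand from Glucagon receptor (Homo sapiens), in the presence of a further agent that is not named here (a lower number here means a stronger inhibitor, a higher number a weaker inhibitor), the highest of the three numbers known here. Compound 1 `CCCC(Nc1ccc(-n2cc(C(F)(F)F)cn2)nc1)c1ccc(C(=O)NCCC(=O)O)cc1` gives 170 nM and compound 3 `CC(C)CC(Oc1ccc(-n2cc(C(F)(F)F)cn2)cc1)c1ccc(C(=O)NCCC(=O)O)cc1` gives 549 nM in this assay; both of those gaps to compound 2 lie beyond the usual scatter, so compound 2 is the weakest inhibitor of the three measured. Compound 4 `CCCC(Oc1ccc(-n2cc(Cl)cn2)cc1)c1ccc(C(=O)NCCC(=O)O)cc1` is not yet measured. It differs from compound 2 in one place: chloro in place of dimethylcarbamoyl on an aromatic carbon. Within the data shown here, no measured pair shows this exact exchange. Compounds 1 and 3 carry trifluoromethyl at that same ring position and give markedly lower numbers than compound 2, but they also differ from it elsewhere, so they only hint at the direction. On that hint, compound 4 is expected to give a lower number than compound 2, with a step of an 11-fold lower number from compound 2 to compound 4 (1.03 log units; beyond the scatter) beyond the scatter. The estimate for compound 4 in this assay is 600 nM, within a range of 150 nM to 2500 nM.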

Compound 4, inhibition constant: 1100 nM
The estimate for compound 4 lay 1.8-fold (0.26 log units) below the measured number, and the stated range covers the measured number.
By their numbers in this assay, from the lowest: compound 1; then compounds 3 and 4 (each within the scatter of the next); then compound 2.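

In (this assay), replacing dimethylcarbamoyl with chloro on this aromatic carbon of the five-membered ring gives a modest step (a 5.9-fold lower number from compound 2 to compound 4 (0.77 log units; beyond the scatter)) that lies beyond the scatter. Within the data shown here, this is the first view of this position with the rest of the molecule unchanged, whereas compound 1 and compound 3 carry trifluoromethyl there but also differ from compound 2 elsewhere. It shows that the substituent at this carbon alone moves the number, although nothing available here explains why.

The compounds shown leave open whether trifluoromethyl on the exact core of compound 4 would give a number different from chloro. Also open, from the compounds shown here alone, is how a primary carboxamide, a nitrile or a methyl group at this carbon would read.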